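Swapping the aryl group on a ring nitrogen

The source may hold more compounds than are shown below. What is called first, only, known or untested is meant among the compounds shown, and "the series" means these compounds.

Of the compounds shown here, three sharing one core have been measured in a functional assay on PC-12 cells (Rattus norvegicus) for cytotoxicity, read by MTT assay, with stated times of 2 h and 24 h, tested at 10 uM; on this read-out higher numbers stand for a stronger effect at the one concentration tested and lower numbers for a weaker effect. Compound 1 `Cc1ccc(-n2nc(-c3ccc(C(F)(F)F)cc3O)nc2-c2ccccc2O)cc1` gives 102%. Compound 2 `Oc1cc(C(F)(F)F)ccc1-c1nc(-c2ccccc2O)n(-c2ccc(F)cc2)n1` gives 99.8%, and compound 3 `COc1ccc(-n2nc(-c3ccc(C(F)(F)F)cc3O)nc2-c2ccccc2O)cc1` gives 98.9%. The three numbers sit close together: the step of a number 2.2 percentage points lower from compound 1 to compound 2 (within the scatter), the step of a number 3.1 percentage points lower from compound 1 to compound 3 (within the scatter) and the step of a number 0.9 percentage points lower from compound 2 to compound 3 (within the scatter) all fall within the scatter, so compound 3 stands among, not apart from, the other two.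

Compound 4 `Oc1cc(C(F)(F)F)ccc1-c1nc(-c2ccccc2O)n(-c2ccccc2Cl)n1` has not been measured. It differs from compound 3 in one place: 2-chlorophenyl in place of 4-methoxyphenyl on an aromatic nitrogen. For the measured compounds named here, no measured step makes exactly this exchange. Going by the values given here, the three measured steps, each swapping a small group on the same aryl ring, stayed within the scatter, and they are the only guidance. On that basis the expected step is a number 0.1 percentage points higher from compound 3 to compound 4 (within the scatter), with no direction beyond the scatter. Compound 4 is therefore estimated at 99%, with a range from 89% to 108%.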

Compound 4, a percentage reported as activity, at one concentration (the size of the read-out at that concentration, not a potency): 102%
Compound 4: the middle estimate sits 3 percentage points below what was measured, within the range that was stated.
By their numbers in this assay, from the lowest: compounds 3, 2, 1 and 4 (each within the scatter of the next).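

The earlier compounds shown here carried 4-methylphenyl, 4-fluorophenyl or 4-methoxyphenyl on the aromatic nitrogen, and the 2-chlorophenyl group of compound 4 brings a chlorine and a different substitution pattern on that aryl ring, yet in this assay the steps are a number 3.1 percentage points higher from compound 3 to compound 4 (within the scatter), a number 2.2 percentage points higher from compound 2 to compound 4 (within the scatter) and no change at the digits printed from compound 1 to compound 4 (within the scatter). Across these four compounds, then, a larger change to the aryl group at this position still gives no step beyond the scatter. Nothing available here explains why the numbers stay together.

Still open, going by these compounds, is whether this holds for a group on that nitrogen without an aromatic ring, such as a longer alkyl chain, or for an aryl ring carrying an amine or a carboxylic acid. All four compounds also share the rest of the core, so they say nothing about changing the 2-hydroxyphenyl group.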